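A few compounds are considered here, and "the series" means these few. Any claim that something is new, unique, unknown or untested is made for them only; others in the source may bear on it.

Measured so far in an ADME assay for permeability; on this read-out lower numbers stand for lower permeability and higher numbers for higher permeability
- compound 1 `CNC(=O)c1cc(C(=O)N[C@H]2[C@@H]3C[C@@H](OC)C[C@@H]32)n([C@@H](C)c2ccccc2)n1` gives 440 nm/s
- compound 2 `CNC(=O)c1cc(C(=O)NC2CC2)cn([C@H](C)c2ccccc2)c1=O` gives 160 nm/s
- compound 3 `CC(=O)Nc1c(F)cc(C(=O)N[C@H]2CC[C@H](O)CC2)cc1O[C@@H](C)c1ccccc1` gives 17 nm/s

Compound 1 has the highest number of the three, and its gaps to compound 2 and to compound 3 both lie beyond the usual scatter of repeated measurements. The next compound, compound 4 `CNC(=O)c1cc(C(=O)N[C@H]2CC[C@H](O)CC2)n([C@@H](C)c2ccccc2)n1`, keeps the core of compound 1 and changes one group on an amide-type nitrogen (a group of 7 heavy atoms (6 carbon, 1 oxygen; one six-membered non-aromatic ring of carbon only) in place of a group of 8 heavy atoms (7 carbon, 1 oxygen; one three-membered non-aromatic ring of carbon only, one five-membered non-aromatic ring of carbon only), on an amide-type nitrogen). Within the data shown here, no two measured compounds differ in only one place, so this swap has no direct precedent. Among the measured compounds shown here, the one indirect hint comes from compound 3 (17 nm/s), the only measured compound that carries the 4-hydroxycyclohexyl group, though on a different core. That hint is weak, but it points to a moderate fall in this assay rather than no change. The expected change is a 3.7-fold lower number from compound 1 to compound 4 (0.56 log units; beyond the scatter) as a rough estimate. For compound 4 the estimated value is 120 nm/s, with an expected range from 40 nm/s to 300 nm/s (a wide range, given so little evidence).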

Compound 4, apparent permeability: 80 nm/s
Compound 4: middle estimate off by 1.5-fold (0.18 log units), on the high side; measured number inside the range.
By their numbers in this assay, from the lowest: compound 3; then compounds 4 and 2 (each within the scatter of the next); then compound 1.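

Among these compounds, with the core of compound 1 held fixed, replacing the group that carries a three-membered and a five-membered ring with 4-hydroxycyclohexyl gives the first direct reading at this amide-type nitrogen in this assay: a 5.5-fold lower number from compound 1 to compound 4 (0.74 log units; beyond the scatter). The group on this nitrogen can therefore move the number by itself, with nothing else in the molecule changed. The entering group carries a hydrogen-bond donor that the leaving group lacks, but no measurement available here ties the drop to that difference or to the change in rings.

As far as these compounds go, whether the hydroxyl matters remains open, and plain cyclohexyl or 4-methoxycyclohexyl on the same nitrogen would help separate it from the ring change. Also open, from the compounds shown here alone, is how an amine or a carboxylic acid on that ring would read in this assay.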